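A few compounds are considered here, and "the series" means these few. Any claim that something is new, unique, unknown or untested is made for them only; others in the source may bear on it.

Compound 1, `CCN(CC)CN1C(=O)/C(=N/NC(=S)Nc2ccc(Cl)cc2)c2ccccc21`, gives in an ADME assay on HeLa cells (Homo sapiens) for cytotoxicity (on this read-out higher numbers stand for lower toxicity in this test and lower numbers for higher toxicity in this test), a value of >= 4000 nM, which is a limit of the assay.
Compound 2, `CCN(CC)CN1C(=O)/C(=N/NC(N)=S)c2cc(Cl)ccc21`, gives in this assay a value of > 100000 nM, also a limit.
Compound 3, `CCN(CC)CN1C(=O)/C(=N/NC(=S)Nc2ccc(C)cc2)c2ccccc21`, gives in this assay a value of >= 20000 nM, again a limit.

Compound 3 thus stands only at a limit, as do the other two values shown, one of them at the limit of > 100000 nM in this assay, at which 1 of the 3 values shown sits, and one at the limit of >= 4000 nM in this assay, at which 1 of the 3 values shown sits, with compound 3 itself at the limit of >= 20000 nM in this assay, at which 1 of the 3 values shown sits. Within the data shown here, the single step between measured compounds, a step that the two limits leave unreadable from compound 1 to compound 3, cannot be read because both ends are limits.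

Compound 4, `CCN(CC)CN1C(=O)/C(=N/NC(N)=S)c2ccccc21`, is the unmeasured compound. It differs from compound 3 by hydrogen in place of 4-methylphenyl on an amide-type nitrogen. Among the measured compounds shown here, no measured step bears on this change, since compound 2 carries the same amino group but on a different core and no step to it is available. Compound 4 is therefore expected to remain at a limit in this assay, with an estimated value of 100000 nM within 20000 nM to 200000 nM. The step from compound 3 to compound 4 is expected at a step that the limit leaves unreadable from compound 3 to compound 4, its true size unreadable.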

Compound 4, minimum cytotoxic concentration: > 100000 nM
Compound 4 gave a limit, no number; the forecaster's own chance of this, stated with the estimate: 75%; the middle value sits exactly at the limit.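

In this assay compound 4 gives > 100000 nM, a limit and not a number. All four values are limits, so the steps from compound 1, compound 2 and compound 3 to compound 4 cannot be read. The compounds shown leave open the true size of any of these changes.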